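The source may report more compounds than this note shows. Statements on the series, on what has been measured and on what is new or still open speak of the compounds shown alone.

Measured so far in a functional assay on KOPN-8 cells (Homo sapiens) for antiproliferative activity, with a stated time of 72 h; on this read-out lower numbers stand for an effect already at smaller amounts and higher numbers for an effect only at larger amounts of compound:
compound 1 `COC(=O)c1cc(=O)c2cc(N)ccc2[nH]1` — > 33700 nM.
compound 2 `COc1ccc(-c2cc(=O)c3c(OC)cc(OC)cc3n2S(=O)(=O)c2ccc([N+](=O)[O-])cc2)cc1` — 17300 nM.

In this assay the figure of compound 1 is a limit of the assay, not a number. Compound 2 therefore stands on the only number shown in this assay, with 17300 nM. Compound 3 `COc1ccc(-c2cc(=O)c3c(OC)cc(OC)cc3n2S(=O)(=O)c2c(F)c(F)c(F)c(F)c2F)cc1` differs from compound 2 in one place: 2,3,4,5,6-pentafluorophenyl in place of 4-nitrophenyl on a sulfonyl sulfur. Going by the values given here, no step between measured compounds is known here, so the expectation rests on compound 2 alone; a step from compound 2 to compound 3 of a 1.2-fold lower number from compound 2 to compound 3 (0.06 log units; within the scatter) is expected, that is none beyond the usual scatter. Compound 3 is estimated at 15000 nM, from 5000 nM to 45000 nM.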

Compound 3, half-maximal effective concentration: > 34400 nM
Compound 3 ended at the assay's limit; the forecaster's own chance of this, stated with the estimate: 30%; at least 2.2-fold (0.36 log units) between middle value and limit.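

In this assay compound 3 gives > 34400 nM, which is a limit of the assay and not a number. Going by these compounds alone, putting 2,3,4,5,6-pentafluorophenyl in place of 4-nitrophenyl on the sulfonyl sulfur gives the first readable step at this position, an at least 1.9-fold higher number from compound 2 to compound 3 (0.29 log units; that floor lies within the scatter). The change shows no gain on this assay, but a loss beyond the scatter is not established.

From the compounds shown here alone, the true size of the step stays open, with only a limit for compound 3. Also open, going by these compounds, is how a 4-aminophenyl or a methyl group on the sulfonyl sulfur would read.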